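Trimming the piperidine substituent in an MCH receptor 1 series

The source may report more compounds than this note shows. Statements on the series, on what has been measured and on what is new or still open speak of the compounds shown alone.

Measured so far:
compound 1 `Cc1nc(N2CCC(NS(=O)(=O)N(C)C)CC2)nc2ccc(NC(=O)/C=C/c3ccc(OC(F)(F)F)cc3)cc12` 105 nM
compound 2 `COCCC1(O)CCN(c2nc(C)c3cc(NC(=O)/C=C/c4ccc(Cl)cc4)ccc3n2)CC1` 245 nM
compound 3 `COc1ccc(/C=C/C(=O)Nc2ccc3nc(N4CCC(O)(C5CC5)CC4)nc(C)c3c2)cc1` 116 nM

In an assay on CHO-K1 cells for displacement of a labelled ligand from melanin-concentrating hormone receptor 1 (Homo sapiens), read by scintillation proximity assay, with a stated time of 2 h (on this read-out higher numbers stand for weaker inhibition and lower numbers for stronger inhibition), compound 2 gives the highest of the three numbers: compound 3 comes in with a lower number at 116 nM and compound 1 with a lower number still at 105 nM, both gaps beyond the scatter. Compound 4 `Cc1nc(N2CCC(O)CC2)nc2ccc(NC(=O)/C=C/c3ccc(Cl)cc3)cc12` has not yet been measured. Going from compound 2 to compound 4 changes one place only: hydrogen in place of 2-methoxyethyl on a saturated ring carbon. Within the data shown here, no measured pair shows this exact step, so its size is open. A step of modest size is expected in this assay, possibly toward a lower number, since compound 2 stands highest at 245 nM; it may also stay within the scatter. Compound 4 is estimated at 180 nM, with a likely range from 60 nM to 550 nM, meaning an expected step of a 1.4-fold lower number from compound 2 to compound 4 (0.13 log units; within the scatter).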

Compound 4, half-maximal inhibitory concentration: 107 nM
The estimate for compound 4 lay 1.7-fold (0.23 log units) above the measured number, within the range that was stated.
By their numbers in this assay, from the lowest: compounds 1, 4 and 3 (each within the scatter of the next); then compound 2.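

Taking off the 2-methoxyethyl group and leaving hydrogen on the saturated ring carbon gives a 2.3-fold lower number from compound 2 to compound 4 (0.36 log units; beyond the scatter) and so stronger inhibition. This position therefore does not need that chain: on this pair, the plainer 4-hydroxypiperidin-1-yl group beats 4-hydroxy-4-(2-methoxyethyl)piperidin-1-yl. Nothing measured here explains the change. As far as these compounds go, whether a single methyl would behave like hydrogen or like 2-methoxyethyl at this carbon remains open. So does the effect of a longer chain, or of an amine on the same carbon.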